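Swapping a Urea for a Thioester on a Saturated Ring

A few compounds are considered here, and "the series" means these few. Any claim that something is new, unique, unknown or untested is made for them only; others in the source may bear on it.

Of the compounds shown here, three sharing one core have been tested in an ADME assay on microsomes from liver (Homo sapiens) for metabolic stability, read by LC-MS, with NADPH named in the record, with a stated time of 60 min, tested at 1 uM, in the absence of a further agent; on this read-out higher numbers stand for a more stable compound and lower numbers for a less stable compound. Compound 1, with the structure `CC(=O)N[C@@H]1CCN(c2cc(C)nn3c(-c4ccccc4)c(C)nc23)C1`, gives a value that is a limit of this assay, > 95%. Compound 2, with the structure `COc1ccc(-c2c(C)nc3c(N4CC[C@@H](NC(=O)Nc5ccccc5)C4)cc(C)nn23)cc1OC`, also reaches a limit of this assay, > 95%. Compound 3, with the structure `COc1ccc(-c2c(C)nc3c(N4CCN(C(=O)OC(C)(C)C)C4)cc(C)nn23)cc1OC`, sits at a limit as well, > 95%. So compound 2 stands at the limit of > 95% in this assay, at which 3 of the 3 values shown sit, and no compound among the three stands apart from the others.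

The next compound, compound 4, has the structure `COc1ccc(-c2c(C)nc3c(N4CC[C@@H](SC(C)=O)C4)cc(C)nn23)cc1OC`. Compared with compound 2, the change is acetylsulfanyl in place of (phenylcarbamoyl)amino on a saturated ring carbon.

Within the data shown here, since every measured compound sits at the same limit, no measured step shows how large a change of this kind can be. The expected step from compound 2 to compound 4 in this assay is a number at least 25 percentage points lower from compound 2 to compound 4 (beyond the scatter), a loss that may run beyond the scatter. Compound 4 is therefore estimated at 70%, within a range from 30% to 95%.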

Compound 4, percent of the compound remaining: > 95%
Compound 4: no number, only a limit; the forecaster's own chance of this, stated with the estimate: 35%; middle value at least 25 percentage points away from the limit.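

Compound 2 and compound 4 both sit at a limit of this assay, and no size can be read for the step between them. The compounds shown leave open whether acetylsulfanyl and (phenylcarbamoyl)amino on this saturated ring carbon differ in stability at all.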